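Testing One Inverted Stereocentre Against a Limit

The source may report more compounds than this note shows. Statements on the series, on what has been measured and on what is new or still open speak of the compounds shown alone.

In a functional assay on K562 cells (Homo sapiens) for inhibition, read by MTT assay, with a stated time of 24 h (on this read-out lower numbers stand for stronger inhibition and higher numbers for weaker inhibition), compound 1 `CCOC1c2cc(OCc3cc(C)cc(C)c3)c(OCc3cc(C)cc(C)c3)cc2CCN1C(=O)OC(C)(C)C` gives > 20000 nM, which is a limit of the assay and not a number. Compound 2 `CC[C@@H]1C[C@H](O)C/C=C(/C)[C@H]2c3cc(OCc4ccccc4)c(OCc4ccccc4)cc3CCN12`, with its different, larger framework around the shared benzyl-type ethers, gives > 20000 nM, and this too is a limit. Neither compound therefore has a measured potency, and both sit at the limit of > 20000 nM in this assay, at which 2 of the 2 values shown sit.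

Compound 3 `CC[C@@H]1C[C@@H](O)C/C=C(/C)[C@H]2c3cc(OCc4ccccc4)c(OCc4ccccc4)cc3CCN12` is the stereoisomer of compound 2, and the change is the two compounds have the same atoms and bonds and differ only in configuration as drawn: 1 of 4 stereo elements differ; a stereocentre at a saturated ring carbon is drawn R in compound 2 and S in compound 3. Within the data shown here, the only close guide is compound 2, whose limit of > 20000 nM gives a floor for comparison but no number, so compound 3 is expected to remain in the same range. The expected step of a number no higher from compound 2 to compound 3 (the limit leaves the size open) is none beyond the scatter in this assay, although a single inverted stereocentre leaves some room for a weak measurable value. The assay may well report only a limit again. Compound 3 is estimated at 20000 nM, with an expected range from 6000 nM to 40000 nM.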

Compound 3, half-maximal inhibitory concentration: > 20000 nM
Compound 3: only a limit was reported; the forecaster's own chance of this, stated with the estimate: 70%; the middle value lies on the limit itself.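

In this assay compound 3 gives > 20000 nM, which is a limit and not a number. Among these compounds, compound 2 is also reported only as a limit, so no step between compound 2 and compound 3 can be read. The compounds shown leave open whether the configuration at that saturated ring carbon has any bearing on potency in this assay.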